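One Methoxy Group, Two Cores, One Open Question

This account rests on a few compounds, and the source may have more. Where it says the series, first, only, none or still open, it means among the compounds named here.

Compound 1 `CC1=CC[C@H](C(C)(C)NC(=S)N/N=C/c2ccc(O)cc2)CC1` gives only a limit of the assay, not a number, in a functional assay on U-251 cells (Homo sapiens) for inhibition, read by sulforhodamine B assay, with a stated time of 48 h; a lower number here means a stronger inhibitor of growth, a higher number a weaker inhibitor of growth: > 100000 nM. Compound 2 `COc1cc(/C=N/NC(=S)NC(C)(C)[C@H]2CC=C(C)CC2)ccc1O` gives 32600 nM in this assay. Compound 3 `CC1=CC[C@H](C(C)(C)NC(=S)N/N=C(\C)c2ccccc2)CC1` likewise reaches only a limit in this assay: > 100000 nM.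

Compound 4 `COc1ccc(/C(C)=N/NC(=S)NC(C)(C)[C@H]2CC=C(C)CC2)cc1` has not yet been measured. The change from compound 1 to compound 2 is methoxy in place of hydrogen on an aromatic carbon, and it produced an at least 3.0-fold lower number from compound 1 to compound 2 (0.48 log units; beyond the scatter); two of the three values sit at the limit of > 100000 nM in this assay, at which 2 of the 3 values shown sit. The change from compound 3 to compound 4 is methoxy in place of hydrogen on an aromatic carbon, the same kind of change rather than the same one: in compound 2 the methoxy sits ortho to a hydroxy group and meta to a large group, in compound 4 it sits para to a large group. How the core of compound 3 differs from the core of compound 1 is not broken down here. Compound 4 is expected to show an at least 2.0-fold lower number from compound 3 to compound 4 (0.30 log units; that floor lies within the scatter), an expectation resting on an at least 3.0-fold lower number from compound 1 to compound 2 (0.48 log units; beyond the scatter). A limit for compound 4 remains quite possible. The estimate for compound 4 is 50000 nM, between 15000 nM and 100000 nM.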

Compound 4, concentration for total growth inhibition: > 100000 nM
Compound 4 ended at the assay's limit; the forecaster's own chance of this, stated with the estimate: 50%; middle value at least 2.0-fold (0.30 log units) away from the limit.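

Among the compounds shown here, compound 4, like compound 3, ended at a limit of this assay and not at a number, so no step between compound 3 and compound 4 can be read: the limit of > 100000 nM in this assay, at which 3 of the 4 values shown sit.

Going by these compounds, whether methoxy in place of hydrogen lowers the number on the core of compound 3, as it did on the core of compound 1, stays open.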